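Three Aryl Variants at the Limit, a Fourth Awaited

The compounds below may be only part of what the source reports. "The series", "measured", "known", "first", "only" and "open" are said of these compounds alone.

In an ADME assay on HUVEC cells (Homo sapiens) for antiproliferative activity, read by MTT assay, with a stated time of 48 h (a higher number here means a weaker inhibitor, a lower number a stronger inhibitor), the three measured compounds stand as follows:

compound 1, `CC(=O)Nc1ccc(-n2nncc2CN2C(=O)C3(C(C#N)=C(N)Oc4c(N)cc5nc6ccccc6nc5c43)c3ccccc32)cc1`, gives > 50000 nM
compound 2, `N#CC1=C(N)Oc2c(N)cc3nc4ccccc4nc3c2C12C(=O)N(Cc1cnnn1-c1c(F)cccc1F)c1ccccc12`, gives > 50000 nM
compound 3, `N#CC1=C(N)Oc2c(N)cc3nc4ccccc4nc3c2C12C(=O)N(Cc1cnnn1-c1ccc(Cl)cc1[N+](=O)[O-])c1ccccc12`, gives > 50000 nM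

Each of these three values is a limit of the assay and not a number. Compound 3 therefore stands at the limit, as do the other two values shown (the limit of > 50000 nM in this assay, at which 3 of the 3 values shown sit). The three steps between the measured compounds, a step that the two limits leave unreadable from compound 1 to compound 2, a step that the two limits leave unreadable from compound 1 to compound 3 and a step that the two limits leave unreadable from compound 2 to compound 3, are all left unreadable by the two limits, so no step size can be taken from them.

Compound 4, `N#CC1=C(N)Oc2c(N)cc3nc4ccccc4nc3c2C12C(=O)N(Cc1cnnn1-c1c(Cl)cc(Cl)cc1Cl)c1ccccc12`, has not yet been measured in this assay. It differs from compound 3 in one place: 2,4,6-trichlorophenyl in place of 4-chloro-2-nitrophenyl on an aromatic nitrogen. All three measured steps in this series change the group on the same aromatic nitrogen, and none of them moved a compound off the limit. From this, compound 4 is expected to remain at the limit as well, with a step that the limit leaves unreadable from compound 3 to compound 4 estimated from compound 3. The estimate for compound 4 in this assay is 60000 nM, expected to fall between 30000 nM and 150000 nM, with a limit rather than a number being the likely report.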

Compound 4, half-maximal inhibitory concentration: 18300 nM
Estimate against measurement, compound 4: 3.3-fold (0.52 log units) above, outside the stated range (below it).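

In this assay, this aromatic nitrogen proves able to carry a group that brings a compound off the limit: 2,4,6-trichlorophenyl gives an at least 2.7-fold lower number from compound 3 to compound 4 (0.43 log units; beyond the scatter) and an at least 2.7-fold lower number from compound 2 to compound 4 (0.43 log units; beyond the scatter) and an at least 2.7-fold lower number from compound 1 to compound 4 (0.43 log units; beyond the scatter). Going by these compounds, the true size of each of these steps stays open, as each starts from a limit and not a number, and the steps among compound 1, compound 2 and compound 3 cannot be read at all. Among these compounds, the group on this nitrogen therefore does matter in this assay, a point that the three earlier compounds could not show, and compound 4 is the only compound off the limit: the limit of > 50000 nM in this assay, at which 3 of the 4 values shown sit.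

The compounds shown leave open which part of 2,4,6-trichlorophenyl goes with the change, since a plain phenyl, a 4-chlorophenyl or a 2,6-dichlorophenyl on the same nitrogen would be needed to separate the contribution of each chlorine. They also leave open whether a 2,4,6-tribromophenyl or a 2,4,6-trimethylphenyl there would carry the number further down or return it to the limit.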